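Epimer step on the cyanosugar ring of the adenine nucleoside

The source may report more compounds than this note shows. Statements on the series, on what has been measured and on what is new or still open speak of the compounds shown alone.

Measured in an ADME assay on cells (kidney, Oryctolagus cuniculus) for cytotoxicity (on this read-out lower numbers stand for higher toxicity in this test and higher numbers for lower toxicity in this test), so far:
compound 1 `CC(C)(C)[Si](C)(C)OC[C@H]1O[C@@H](n2cnc3c(N)ncnc32)[C@H](O[Si](C)(C)C(C)(C)C)[C@@H]1C#N`: 10 ug/mL
compound 2 `N#C[C@@H]1[C@@H](O)[C@H](n2cnc3c(N)ncnc32)O[C@@H]1CO`: 200 ug/mL

Going by the values given here, compound 2 holds the highest of the two numbers in this assay; its only neighbour, compound 1, gives 10 ug/mL, a far lower number that lies beyond the usual scatter. Among the compounds with values here, no step between these two is worked out here, since they differ in more than one place, so only the two values themselves are to be read.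

Compound 3 `N#C[C@H]1[C@@H](O)[C@H](n2cnc3c(N)ncnc32)O[C@@H]1CO` is the next member. Against compound 2 the change is the two compounds have the same atoms and bonds and differ only in configuration as drawn: 1 of 4 stereo elements differ; a stereocentre at a saturated ring carbon is drawn R in compound 2 and S in compound 3. Nothing measured in the series speaks to such a configurational change, so the step from compound 2 to compound 3 is expected to stay within the scatter, as no change at the digits printed from compound 2 to compound 3 (within the scatter) expresses. For compound 3 the value in this assay is estimated at 200 ug/mL, with a range from 100 ug/mL to 400 ug/mL.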

Compound 3, minimum cytotoxic concentration: > 400 ug/mL
Compound 3 ended at the assay's limit; the forecaster's own chance of this, stated with the estimate: 30%; middle value at least 2.0-fold (0.30 log units) from the limit.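

In this assay compound 3 sits at a limit of the test, > 400 ug/mL, which is a limit and not a number. Going by these compounds, the series now has its first step in one place, an at least 2.0-fold higher number from compound 2 to compound 3 (0.30 log units; that floor lies within the scatter); this is only a floor, so the true size of the step stays open, and the configuration at this saturated ring carbon can be neither credited with an effect nor cleared of one. What the pair does offer is a comparison free of any change in atoms or bonds: the fact that compounds 2 and 3 differ only in the configuration as drawn.

Whether a wider gap between the two epimers lies past the limit remains unresolved. The compounds shown also leave open how this assay responds when a carboxylic acid or an aminomethyl group takes the place of the nitrile on either epimer.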